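The source may report more compounds than this note shows. Statements on the series, on what has been measured and on what is new or still open speak of the compounds shown alone.

Compound 1 `Cc1nn(-c2ncnc3nc[nH]c23)c2c1C(OCc1ccccc1F)CC(=O)N2`: 78 nM in a functional assay on HEK293 cells for agonist activity at G-protein coupled receptor 39 (Homo sapiens), read by scintillation proximity assay and inositol phosphate accumulation, with a stated time of 75 min; a higher number here means that more compound is needed for the effect, a lower number that less compound is needed
Compound 2 `CCCCCCCCOC1CC(=O)Nc2c1c(C)nn2-c1ncnc2nc[nH]c12`: 388 nM
Compound 3 `Cc1nn(-c2ncnc3nc[nH]c23)c2c1C(OCc1ccccc1C#N)CC(=O)N2`: 127 nM

Compound 2 stands highest of the three numbers in this assay, so it needs the most compound for the effect. Its nearest neighbour is compound 3, reached by a 3.1-fold lower number from compound 2 to compound 3 (0.49 log units; beyond the scatter), and the gap to compound 1 is larger still, a 5.0-fold higher number from compound 1 to compound 2 (0.70 log units; beyond the scatter). Compound 4 `Cc1nn(-c2ncnc3nc[nH]c23)c2c1C(C(=O)N(C)c1ccccc1)CC(=O)N2` has not yet been measured. Its change from compound 2 is methyl(phenyl)carbamoyl in place of octyloxy on a saturated ring carbon. For the measured compounds named here, two measured steps bear on this: each time the long saturated chain of compound 2 was exchanged for a group carrying a six-membered aromatic ring, the number fell, as seen in a 3.1-fold lower number from compound 2 to compound 3 (0.49 log units; beyond the scatter) and, read in reverse, a 5.0-fold higher number from compound 1 to compound 2 (0.70 log units; beyond the scatter). Going by the values given here, no measured step, however, covers exchanging the ether oxygen of the chain for a carbamoyl group, so the size of the step is uncertain. A modest lowering is expected for compound 4, a 2.6-fold lower number from compound 2 to compound 4 (0.41 log units; beyond the scatter). The estimate for compound 4 is 150 nM, with a range from 40 nM to 600 nM.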

Compound 4, half-maximal effective concentration: 5220 nM
Beside the measured number, compound 4's estimate is 35-fold (1.54 log units) below it, and the stated range ends below it.
By their numbers in this assay, from the lowest: compounds 1 and 3 (each within the scatter of the next); then compound 2; then compound 4.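

A ring-bearing group at this saturated ring carbon does not by itself bring the number down: methyl(phenyl)carbamoyl in place of octyloxy gives a 13-fold higher number from compound 2 to compound 4 (1.13 log units; beyond the scatter), so this group does worse than the long chain. The loss is larger against the two benzyl ethers, with a 41-fold higher number from compound 3 to compound 4 (1.61 log units; beyond the scatter) and a 67-fold higher number from compound 1 to compound 4 (1.83 log units; beyond the scatter), which shows that the aromatic ring alone does not carry the lower numbers of those compounds. No measurement shown here explains this loss.

From the compounds shown here alone, the new group differs from the ethers in its carbonyl, its nitrogen and its methyl all at once, so the part responsible remains open. Phenylcarbamoyl without the methyl, or benzylamino on the same carbon, could help separate these parts.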